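Alkynyl series: cyclopentyl to 1-methylethenyl at the alkyne

This account rests on a few compounds, and the source may have more. Where it says the series, first, only, none or still open, it means among the compounds named here.

Two compounds of the series have been run so far in a functional assay on 1321-N1 cells for agonist activity at Free fatty acid receptor 1 (Homo sapiens), read by calcium flux, with a stated time of 0.4 s; on this read-out higher numbers stand for larger maximal responses and lower numbers for smaller maximal responses. Compound 1 `O=C(O)CCc1ccc(C#CC2CCCC2)cc1` gives 94% in this assay. Compound 2 `C/C=C\C#Cc1ccc(CCC(=O)O)c(F)c1` gives 91% in this assay. The two numbers sit within the usual scatter of each other, so compound 1 cannot be set apart from compound 2 on this read-out; both reach essentially the full response of the reference. Among the compounds with values here, no pair of measured compounds differs in a single place, so no measured step is available to lean on.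

Compound 3 `C=C(C)C#Cc1ccc(CCC(=O)O)cc1` is the next compound to be measured. It differs from compound 1 as follows: 1-methylethenyl in place of cyclopentyl on a triple-bonded carbon. The carboxylic acid and the shared core stay as they are; only the group on the triple-bonded carbon changes. Compound 2, which also carries a small unsaturated chain on its alkyne, gives 91% in this assay, which is the only hint about how such a chain behaves here. For compound 3 no step beyond the scatter is expected, a number 4 percentage points lower from compound 1 to compound 3 (within the scatter) being the estimated step, with the value for compound 3 expected at 90%, in the range 75% to 102%.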

Compound 3, largest response reached (reported as efficacy), in percent of the reference or control that the assay uses: 108%
Compound 3: the middle estimate sits 18 percentage points below what was measured, outside the stated range (above it).
By their numbers in this assay, from the lowest: compounds 2 and 1 (each within the scatter of the next); then compound 3.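

Notes on the group on the triple-bonded carbon: in this assay this position is not silent for maximal response, as the change from cyclopentyl to 1-methylethenyl gives a number 14 percentage points higher from compound 1 to compound 3 (beyond the scatter) and provides the first single-place step in the series. The ring is not needed to retain the response on this core, since compound 3 gives 108% with an open group of fewer heavy atoms and one double bond outside aromatic rings. Both groups have no hydrogen-bond donors, no hydrogen-bond acceptors and no net charge, so those counts do not distinguish them, and no available data explain the step.

As far as these compounds go, whether the higher response follows the double bond, the loss of the ring or the smaller number of heavy atoms remains open, as this single step changes all three together. From the compounds shown here alone, an isopropyl group on the same triple-bonded carbon would test the double bond with the open shape retained, while a cyclopropyl group would test a smaller carbon ring, and the response to either remains unknown.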